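The source may report more compounds than this note shows. Statements on the series, on what has been measured and on what is new or still open speak of the compounds shown alone.

Among the measured compounds shown here, compound 1 `Cc1ccc2[nH]c(=O)c(/C=N/c3ccccc3O)cc2c1` gives 26200 nM in a functional assay, read by spectrophotometry, with a stated time of 30 min (a lower number here means a stronger inhibitor, a higher number a weaker inhibitor), and stands lowest of the three numbers measured so far. Compound 2 `Cc1ccc2[nH]c(=O)c(/C=N/O)cc2c1` gives 160000 nM and compound 3 `Cc1ccc2[nH]c(=O)c(/C=N/CCO)cc2c1` gives 498000 nM in the same assay. The measured steps are a 6.1-fold higher number from compound 1 to compound 2 (0.79 log units; beyond the scatter), a 19-fold higher number from compound 1 to compound 3 (1.28 log units; beyond the scatter) and a 3.1-fold higher number from compound 2 to compound 3 (0.49 log units; beyond the scatter), and all three exchange the group on the double-bonded nitrogen while the core of compound 1 is kept unchanged. For the measured compounds named here, compound 4 `O=c1[nH]c2ccccc2cc1/C=N/c1ccccc1O` differs from compound 1 by hydrogen in place of methyl on an aromatic carbon, a change at the core that no measured step touches, so none of the three steps bears on it directly. With the group on the double-bonded nitrogen of compound 1 retained, a step in this assay within the usual scatter is expected, with no clear direction. For compound 4 the estimate is 35000 nM, with a range from 12000 nM to 100000 nM. This estimate corresponds to an expected step of a 1.3-fold higher number from compound 1 to compound 4 (0.13 log units; within the scatter).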

Compound 4, half-maximal inhibitory concentration: 22800 nM
Compound 4: the middle estimate sits 1.5-fold (0.19 log units) above what was measured; the range from low to high includes it.
By their numbers in this assay, from the lowest: compounds 4 and 1 (each within the scatter of the next); then compound 2; then compound 3.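

In this assay, among the compounds shown here, hydrogen in place of methyl on an aromatic carbon gives a 1.1-fold lower number from compound 1 to compound 4 (0.06 log units; within the scatter), the first measured step at the shared core rather than on the double-bonded nitrogen. With 2-hydroxyphenyl retained, the methyl is therefore not required at this position for the inhibition seen with compound 1. No evidence on the origin of this result is available.

As far as these compounds go, whether a larger group here, such as methoxy, chlorine or an amine, would leave the number unmoved remains open. Also open, from the compounds shown here alone, is whether the methyl matters when hydroxy or 2-hydroxyethyl sits on the double-bonded nitrogen.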